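This account rests on a few compounds, and the source may have more. Where it says the series, first, only, none or still open, it means among the compounds named here.

Working notes on the series.

Compound 1 `COc1cccc(C(=O)c2ccc3c(ccn3S(=O)(=O)c3cccc(/C=C/C(=O)NO)c3)c2)c1` and compound 2 `Cc1ccc(C(=O)c2ccc3c(ccn3S(=O)(=O)c3cccc(/C=C/C(=O)NO)c3)c2)cc1` share a core and differ only in the group on the carbonyl carbon. In an assay on isolated protein for inhibition of histone deacetylase 8 (Homo sapiens) (on this read-out higher numbers stand for weaker inhibition and lower numbers for stronger inhibition), compound 1 gives 3530 nM, and compound 2 gives 4480 nM. The change 3-methoxyphenyl in place of 4-methylphenyl on a carbonyl carbon produced a 1.3-fold lower number from compound 2 to compound 1 (0.10 log units; within the scatter), so the two values are treated as equivalent here.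

Compound 3 `Cc1ccc(C(=O)c2ccc3c(ccn3Cc3ccc(C(=O)NO)cc3)c2)cc1` carries the same 4-methylphenyl on the carbonyl carbon as compound 2 but has a different core; the difference between the two cores is not broken down here. In this assay compound 3 gives 1490 nM, the lowest of the three numbers. Compound 1 and compound 2 both sit a higher number away, in each case beyond the scatter, so compound 3 is the strongest inhibitor of the three measured.

Compound 4 `COc1cccc(C(=O)c2ccc3c(ccn3Cc3ccc(C(=O)NO)cc3)c2)c1` is not yet measured. It relates to compound 3 by 3-methoxyphenyl in place of 4-methylphenyl on a carbonyl carbon, the same change, at the same place, that converts compound 2 into compound 1. Among the measured compounds shown here, since that earlier change gave a 1.3-fold lower number from compound 2 to compound 1 (0.10 log units; within the scatter), a step of similar size is expected here, estimated as a 1.2-fold lower number from compound 3 to compound 4 (0.09 log units; within the scatter), resting on the single measured pair compound 2 to compound 1. The expectation for compound 4 in this assay is therefore a value near that of compound 3, estimated at 1200 nM with a likely range from 500 nM to 3000 nM.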

Compound 4, half-maximal inhibitory concentration: 1120 nM
Beside the measured number, compound 4's estimate is 1.1-fold (0.03 log units) above it; low and high end bracket the measured number.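

In this assay the change from 4-methylphenyl to 3-methoxyphenyl on the carbonyl carbon is a small one on the core of compound 3 (a 1.3-fold lower number from compound 3 to compound 4 (0.12 log units; within the scatter)), and compound 3 and compound 4 are treated as equivalent here. Set beside the earlier pair, the change reads alike on both cores: the same change on two cores in this assay, a 1.3-fold lower number (0.10 log units; within the scatter) from compound 2 to compound 1 and a 1.3-fold lower number (0.12 log units; within the scatter) from compound 3 to compound 4, 1.0-fold (0.02 log units) apart, within the scatter of two such steps. This shows that, for this one pair of groups, the step stays within the scatter on each of the two cores, but it does not show that a step of real size would carry from one core to the other, and two pairs set no rule for further cores or further groups.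

The compounds shown leave open whether a group further removed from these two on the carbonyl carbon, such as an amine, a carboxylic acid or a longer chain, would also read alike on both cores. They also leave open which part of the difference between the two cores matters in this assay, as no pair shown changes one part of that difference alone.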